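The source may hold more compounds than are shown below. What is called first, only, known or untested is meant among the compounds shown, and "the series" means these compounds.

Measured so far:
- compound 1 `CS(=O)(=O)c1cccc(CCCCCCC(=O)c2ncc(-c3ccccn3)o2)c1`, giving 1.3 nM in an assay for inhibition of Fatty-acid amide hydrolase 1 (Rattus norvegicus); on this read-out lower numbers stand for stronger inhibition and higher numbers for weaker inhibition
- compound 2 `Nc1cccc(CCCCCCC(=O)c2ncc(-c3ccccn3)o2)c1`, giving 30 nM in this assay

Compound 2 stands highest of the two numbers in this assay; its nearest neighbour is compound 1, and the step of a 23-fold higher number from compound 1 to compound 2 (1.36 log units; beyond the scatter) separates them, a large one beyond the scatter. Compound 3 `CC(C)(C)OC(=O)Nc1cccc(CCCCCCC(=O)c2ncc(-c3ccccn3)o2)c1` is not yet measured. It differs from compound 2 by tert-butoxycarbonyl in place of hydrogen on a nitrogen on an aromatic ring. Among the compounds with values here, no measured step shows this change directly. Within the data shown here, the one step that bears on it, a 23-fold higher number from compound 1 to compound 2 (1.36 log units; beyond the scatter), shows that what sits at this position of the aromatic ring can move the number a long way, and that the methylsulfonyl of compound 1 gave the lower number. The tert-butoxycarbonyl entering in compound 3 brings two hydrogen-bond acceptors, but it is attached through the nitrogen rather than the ring carbon, so the comparison is loose. On that basis a moderate step towards a lower number is expected in this assay, a 3.0-fold lower number from compound 2 to compound 3 (0.48 log units; beyond the scatter), with wide uncertainty. Compound 3 is therefore estimated at 10 nM in this assay, with a range from 2 nM to 50 nM.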

Compound 3, inhibition constant: 2.4 nM
For compound 3 the middle estimate is 4.2-fold (0.62 log units) above the measured one, and the stated range covers the measured number.
By their numbers in this assay, from the lowest: compounds 1 and 3 (each within the scatter of the next); then compound 2.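

In this assay there is a 13-fold lower number from compound 2 to compound 3 (1.10 log units; beyond the scatter) on placing tert-butoxycarbonyl on the nitrogen, so the high number of compound 2 is not tied to a nitrogen at this ring position as such, since the same nitrogen carrying this group gives a low number. With a 1.8-fold higher number from compound 1 to compound 3 (0.27 log units; within the scatter) separating them, compound 1 and compound 3 cannot be told apart in this read-out, which means that two quite different groups, methylsulfonyl and (tert-butoxycarbonyl)amino, serve equally well here, and among the three compounds only the free amino of compound 2 stands apart from the others beyond the scatter. Nothing available accounts for the size of this step or for the match between the two groups.

The compounds shown leave open how much of the tert-butoxycarbonyl is needed at the nitrogen, for instance whether an acetyl or a methoxycarbonyl there would give a number like that of compound 3. They also leave open how a carboxylic acid or a methylamino group would compare at this same place on the ring.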